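The compounds below may be only part of what the source reports. "The series", "measured", "known", "first", "only" and "open" are said of these compounds alone.

Measured so far in an assay on isolated protein for inhibition of Amine oxidase [flavin-containing] A (Homo sapiens), read by Amplex Red, with a stated time of 15 min, tested at 100 uM; a lower number here means less inhibition, a higher number more inhibition at the concentration tested (going by the name of the read-out):
compound 1 `CC(=O)c1ccc(OCc2ccccc2C)cc1`, 42.9%
compound 2 `CC(=O)c1ccc(OCc2cccc(C)c2)cc1`, 32.3%
compound 3 `CC(=O)c1ccc(OCc2ccc(C)cc2)cc1`, 5.96%

Compound 3 stands lowest of the three; compound 2 sits above it by a margin beyond the scatter, and compound 1 further above still, also beyond the scatter. The three differ only in where the methyl sits on the benzyl ring, and the methyl-bearing benzyl with the methyl para to a large group gives the lowest number here.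

Compound 4 `CC(=O)c1ccc(OCc2ccc([N+](=O)[O-])cc2)cc1` is not yet measured. It differs from compound 3 by nitro in place of methyl on an aromatic carbon. Among the measured compounds shown here, no measured pair shows this change, so the direction is open. A modest upward step is expected, most likely within or just beyond the scatter, since compound 3 starts low with 5.96%. For compound 4 the expected result in this assay is 20%, within 0% to 50%. The expected step is a number 14 percentage points higher from compound 3 to compound 4 (beyond the scatter).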

Compound 4, a percentage reported as inhibition, at one concentration (the size of the read-out at that concentration, not a potency): 33.8%
The estimate for compound 4 lay 13.8 percentage points below the measured number, within the range that was stated.
By their numbers in this assay, from the lowest: compound 3; then compounds 2, 4 and 1 (each within the scatter of the next, the first and the last beyond it).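

In this assay, among the compounds shown here, nitro in place of methyl on an aromatic carbon para to a large group gives a number 27.8 percentage points higher from compound 3 to compound 4 (beyond the scatter), the first step that changes the group rather than where a methyl sits. The low reading of compound 3 is therefore not fixed by this position alone: the group placed there matters. Nothing available explains this step.

Open, as far as these compounds go, is how an amine, a methoxy group or a carboxylic acid would read at this position. Also open, from the compounds shown here alone, is whether nitro elsewhere on the benzyl ring would give a different reading.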